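The compounds below may be only part of what the source reports. "The series", "measured", "known", "first", "only" and "open" are said of these compounds alone.

In a functional assay on UACC-257 cells (Homo sapiens) for inhibition, read by sulforhodamine B assay, with a stated time of 48 h (a higher number here means a weaker inhibitor of growth, a lower number a stronger inhibitor of growth), the measured compounds are:
Compound 1 `COc1cc(-c2nn(-c3cccc(NC(=O)c4cccc(C(F)(F)F)c4)c3)cc2-c2ccncc2)ccc1Cl` with 27900 nM
Compound 2 `COc1cc(-c2nn(-c3cccc(NC(=O)Nc4ccc(Cl)c(Cl)c4)c3)cc2-c2ccncc2)ccc1Cl` with 1040 nM
Compound 3 `COc1cc(-c2nn(-c3cccc(NC(=O)Nc4cccc(C(F)(F)F)c4)c3)cc2-c2ccncc2)ccc1Cl` with 923 nM

Compound 3 and compound 2 cannot be told apart, with a 1.1-fold lower number from compound 2 to compound 3 (0.05 log units; within the scatter) between them. Both lie far from compound 1, as a 30-fold lower number from compound 1 to compound 3 (1.48 log units; beyond the scatter) and a 27-fold lower number from compound 1 to compound 2 (1.43 log units; beyond the scatter) show.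

Compound 4 `COc1cc(-c2nn(-c3cccc(NC(=O)Nc4ccc(Cl)c(C(F)(F)F)c4)c3)cc2-c2ccncc2)ccc1Cl` is compound 3 with one change chloro in place of hydrogen on an aromatic carbon and is chloro in place of hydrogen on an aromatic carbon, ortho to a trifluoromethyl group and para to a large group. The ring thus goes from 3-(trifluoromethyl)phenyl to 4-chloro-3-(trifluoromethyl)phenyl.

The two large steps from compound 1 concern the group on the carbonyl carbon, which this change leaves alone, so they say little here. The closest evidence is the swap of ring substituents in a 1.1-fold lower number from compound 2 to compound 3 (0.05 log units; within the scatter). That swap alters the same ring. Compound 4 carries a chloro as compound 2 does and a trifluoromethyl as compound 3 does, and those two compounds sit within the scatter of each other. Among the compounds with values here, no measured pair shows this exact addition, so the expectation remains uncertain.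

The estimate is a small step of a 1.2-fold lower number from compound 3 to compound 4 (0.09 log units; within the scatter) that is not expected to go beyond the scatter. Compound 4 is expected at 750 nM (estimated range 280 nM to 2000 nM).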

Compound 4, concentration for 50% growth inhibition: 1210 nM
Compound 4: middle estimate off by 1.6-fold (0.21 log units), on the low side; the measured number falls inside the stated range.
By their numbers in this assay, from the lowest: compounds 3, 2 and 4 (each within the scatter of the next); then compound 1.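

In this assay, within the data shown here, chloro in place of hydrogen on this aromatic carbon, ortho to a trifluoromethyl group and para to a large group, gives no step that can be told from the scatter (a 1.3-fold higher number from compound 3 to compound 4 (0.12 log units; within the scatter)). The 3-(trifluoromethyl)phenyl and 3,4-dichlorophenyl rings had already matched each other, and the ring carrying both chloro and trifluoromethyl now matches the dichloro ring as well (a 1.2-fold higher number from compound 2 to compound 4 (0.07 log units; within the scatter)), so all three ring patterns on the amino side of the carbonyl stay within the scatter of one another. The large gap to the compound without that amino group remains (a 23-fold lower number from compound 1 to compound 4 (1.36 log units; beyond the scatter)), although this step also includes the added chloro; nothing measured here offers an explanation for the result.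

On these data alone, whether this aromatic carbon would accept very different groups, such as an amine, a carboxylic acid or a longer chain, stays open. Also open, as far as these compounds go, is whether the same chloro addition would give so small a step on the ring of compound 1, which has no amino group on its carbonyl carbon.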